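From piperidin-4-yl to 3-carboxypropyl on the shared core

The compounds below may be only part of what the source reports. "The series", "measured", "known", "first", "only" and "open" are said of these compounds alone.

Within the data shown here, in a functional assay on MDA-MB-231 cells (Homo sapiens), read by wound healing assay, with a stated time of 24 h (a higher number here means a weaker inhibitor, a lower number a stronger inhibitor), compound 2 (`CC(C)=CCC[C@H](C)c1ccc(C)c2c1OCN(CC1CCNCC1)C2`) gives 8100 nM, the only actual number among the measured compounds. Compound 1 (`CC(C)=CCC[C@H](C)c1ccc(C)c(CNCCO)c1O`) gives > 20000 nM, which is a limit of the assay and not a number. Compound 3 (`CC(C)=CCC[C@H](C)c1ccc(C)c(CNCC2CCNCC2)c1O`) gives > 20000 nM, which is also a limit. The measured set is thus dominated by the limit of > 20000 nM in this assay, at which 2 of the 3 values shown sit.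

The change from compound 2 to compound 4 (`CC(C)=CCC[C@H](C)c1ccc(C)c2c1OCN(CCCCC(=O)O)C2`) is this: 3-carboxypropyl in place of piperidin-4-yl on a saturated chain carbon bound to an amine nitrogen in a ring. Among the measured compounds shown here, the only measured step, a step that the two limits leave unreadable from compound 1 to compound 3, has no readable size, so no measured step sizes this change directly. For the measured compounds named here, the one firm anchor is compound 2 at 8100 nM, and the expectation rests on that value and on the structural change alone. The expected step in this assay is a modest one toward weaker inhibition, estimated as a 1.5-fold higher number from compound 2 to compound 4 (0.17 log units; within the scatter). Compound 4 is estimated at 12000 nM, with an expected range of 4000 nM to 25000 nM.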

Compound 4, half-maximal inhibitory concentration: 29900 nM
Beside the measured number, compound 4's estimate is 2.5-fold (0.40 log units) below it; measured number outside the range, above it.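

In this assay the set now holds a readable step on the shared core, a 3.7-fold higher number from compound 2 to compound 4 (0.57 log units; beyond the scatter), with 3-carboxypropyl in place of piperidin-4-yl on a saturated chain carbon bound to an amine nitrogen in a ring. The two groups match in heavy atoms, hydrogen-bond donors and hydrogen-bond acceptors, yet this swap of a ring for an open chain with a double bond outside aromatic rings moves the number beyond the scatter. The earlier step could not be read, and limits still mark much of the set: the limit of > 20000 nM in this assay, at which 2 of the 4 values shown sit.

From the compounds shown here alone, it remains open whether the step follows the loss of the piperidin-4-yl group or the arrival of the carboxylic acid. An open chain ending in an amine, or a piperidine ring carrying a carboxylic acid, would bear on that question.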